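Demethylating the ether side chain of compound 3

The compounds below may be only part of what the source reports. "The series", "measured", "known", "first", "only" and "open" are said of these compounds alone.

Compound 3 `COCC/C(=C(/c1ccc(/C=C/C(=O)O)cc1)c1ccc2[nH]ncc2c1)c1ccccc1` gives 63 nM in a functional assay on MCF7 cells (Homo sapiens) for cytotoxicity, read by CellTiter-Glo, with a stated time of 5 days (on this read-out lower numbers stand for stronger inhibition and higher numbers for weaker inhibition), the second highest of three numbers: its nearest neighbour is compound 2 `COC/C(=C(/c1ccc(/C=C/C(=O)O)cc1)c1ccc2[nH]ncc2c1)c1ccccc1` with 88 nM, a gap within the scatter, and the furthest is compound 1 `CCCC/C(=C(/c1ccc(/C=C/C(=O)O)cc1)c1ccc2[nH]ncc2c1)c1ccccc1` with 10 nM. The steps seen so far, an 8.8-fold higher number from compound 1 to compound 2 (0.94 log units; beyond the scatter), a 6.3-fold higher number from compound 1 to compound 3 (0.80 log units; beyond the scatter) and a 1.4-fold lower number from compound 2 to compound 3 (0.15 log units; within the scatter), all concern exchanging an alkyl chain for a methoxy-bearing one or lengthening it. Compound 4 `O=C(O)/C=C/c1ccc(/C(=C(/CCO)c2ccccc2)c2ccc3[nH]ncc3c2)cc1` differs from compound 3 by hydrogen in place of methyl on an oxygen on a saturated carbon, that is, 2-methoxyethyl to 2-hydroxyethyl. Among the compounds with values here, no measured step touches the oxygen substituent itself, so nothing beyond the scatter is expected: a 1.1-fold higher number from compound 3 to compound 4 (0.05 log units; within the scatter) is the estimate. Compound 4 is therefore expected to give about 70 nM, between 25 nM and 200 nM.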

Compound 4, half-maximal inhibitory concentration: > 1000 nM
Compound 4: only a limit was reported; the forecaster's own chance of this, stated with the estimate: 2%; middle value at least 14-fold (1.15 log units) from the limit.
By their numbers in this assay, from the lowest: compound 1; then compounds 3 and 2 (each within the scatter of the next). At a limit, above all of these: compound 4.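

The value of compound 4 in this assay is a limit and not a number: the limit of > 1000 nM in this assay, at which 1 of the 4 values shown sits. Hydrogen in place of methyl on the chain oxygen alone gives an at least 15-fold higher number from compound 3 to compound 4 (1.20 log units; beyond the scatter), so this small change at the end of the side chain produces a large step, where the earlier exchanges were modest. The other comparisons are also large, with an at least 11-fold higher number from compound 2 to compound 4 (1.05 log units; beyond the scatter) and an at least 100-fold higher number from compound 1 to compound 4 (2.00 log units; beyond the scatter).

From the compounds shown here alone, how far the number rises beyond the limit remains open. Going by these compounds, it is also open whether the same step would follow with an amine or a carboxylic acid at the end of this chain, or whether a longer chain carrying the hydroxy would behave alike.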